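A few compounds are considered here, and "the series" means these few. Any claim that something is new, unique, unknown or untested is made for them only; others in the source may bear on it.

Values in a functional assay on A-375 cells (Homo sapiens) for antiproliferative activity (on this read-out lower numbers stand for stronger inhibition and higher numbers for weaker inhibition), so far:
- Compound 1 `O=C(Nc1ccc2scnc2c1)C1CCCN(Cc2ccc(F)c(F)c2)C1` gives > 20000 nM which is a limit of the assay.
- Compound 2 `O=C(Nc1ccc(-c2cscn2)cc1)C1CCCN(Cc2ccc3cn[nH]c3c2)C1` gives > 20000 nM which is also a limit of the assay.
- Compound 3 `O=C(Nc1ccc(-c2ccccn2)cc1)C1CCCN(Cc2ccc(F)c(F)c2)C1` gives 9000 nM as a measured number.
- Compound 4 `O=C(Nc1ccc(-c2ccco2)cc1)C1CCCN(Cc2ccc(F)c(F)c2)C1` has not yet been measured.

Compound 3 (at 9000 nM) is the only one of the three with a true number, so it is the sole numerical reference point in this series. Within the data shown here, the other two compounds stand at a limit, and no pair of measured compounds differs in just one place.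

Compound 4 differs from compound 3 in a single group: furan-2-yl in place of pyridin-2-yl on an aromatic carbon, on a six-membered aromatic ring of carbon only, para to a large group. The count runs as follows: furan-2-yl in place of pyridin-2-yl on an aromatic carbon.

Among the measured compounds shown here, with no measured step to draw on, the change in this assay is expected to be small and probably no larger than the scatter. Any lean would be towards weaker inhibition, and that lean rests for compound 3 on its value of 9000 nM and on the wider picture: the limit of > 20000 nM in this assay, at which 2 of the 3 values shown sit. The estimated move is a 1.1-fold higher number from compound 3 to compound 4 (0.05 log units; within the scatter) and it may end at the limit rather than at a number. In this assay compound 4 is estimated at 10000 nM (expected range 4000 nM to 20000 nM).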

Compound 4, half-maximal inhibitory concentration: 1040 nM
Beside the measured number, compound 4's estimate is 9.6-fold (0.98 log units) above it, and the stated range ends above it.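

In this assay, among these compounds, the group on an aromatic carbon, para to a large group, proves able to move the read-out: with furan-2-yl in place of pyridin-2-yl there is an 8.7-fold lower number from compound 3 to compound 4 (0.94 log units; beyond the scatter) and this is the only step that can be read. The two groups have the same counts of hydrogen-bond donors and acceptors and no net charge, while they differ in ring size and in the hetero atom, so those shared counts alone do not follow the change in the read-out. Compound 4 also gives the series a second true number, in a set where the other values are limits of the assay: the limit of > 20000 nM in this assay, at which 2 of the 4 values shown sit.

The compounds shown leave open whether the change belongs to furan-2-yl itself or to a five-membered aromatic ring in general, and a single step cannot separate ring size from the hetero atom. A thiophene ring, a plain phenyl ring or a small amine at this same place would bear on that, as would a second step showing whether the effect holds with a different group elsewhere on the shared core.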